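Carboxymethyl extension from compound 1 to compound 4

The source may report more compounds than this note shows. Statements on the series, on what has been measured and on what is new or still open speak of the compounds shown alone.

Compound 1 `C[C@H]1N=C2C[C@H]3C[C@H](C3(C)C)[C@@]2(C)OC1=O` is the starting point of this step. In an ADME assay on McCoy cells (Mus musculus) for antiproliferative activity, read by sulforhodamine B assay, with a stated time of 48 h (a lower number here means a stronger inhibitor, a higher number a weaker inhibitor), compound 1 gives > 1800000 nM, which is a limit of the assay and not a number; it sits at the limit of > 1800000 nM in this assay, at which 1 of the 3 values shown sits. Compound 2 `CC(C)(C)OC(=O)n1cnc(C[C@H]2N=C3C[C@H]4C[C@H](C4(C)C)[C@@]3(C)OC2=O)c1` likewise gives only a limit in this assay, > 1300000 nM. Compound 3 `CC(C)(C)OC(=O)NCCC[C@@H]1N=C2C[C@@H]3C[C@@H](C3(C)C)[C@]2(C)OC1=O` also reaches only a limit in this assay, > 1200000 nM. Since every value shown is a limit, compound 1 cannot be ordered against compound 2 or compound 3; all that the numbers show is that none of the three reaches a measurable half-maximal inhibitory concentration in this assay.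

Compound 4 `CC1(C)[C@H]2CC3=N[C@H](CCC(=O)O)C(=O)O[C@]3(C)[C@@H]1C2` differs from compound 1 by carboxymethyl in place of hydrogen on a saturated chain carbon bound to a saturated ring carbon. Among the compounds with values here, no step between measured compounds is available, so nothing measured here speaks to the effect of this change. The step of a number no higher from compound 1 to compound 4 (the limit leaves the size open) is expected to be none beyond the scatter, with compound 4 expected to stay at a limit as compound 1 does with > 1800000 nM. For compound 4 the expected value is 1800000 nM, estimated to fall between 600000 nM and 5000000 nM.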

Compound 4, half-maximal inhibitory concentration: > 1200000 nM
Compound 4 ended at the assay's limit (the forecaster's own chance of this, stated with the estimate: 85%); the middle value lies beyond the limit too.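

In this assay compound 4 gives > 1200000 nM, which is a limit of the assay and not a number. Within the data shown here, compound 1 gives > 1800000 nM, also a limit, so no step from compound 1 to compound 4 can be read. The compounds shown leave open whether exchanging methyl for 2-carboxyethyl changes antiproliferative activity at all.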